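This account rests on a few compounds, and the source may have more. Where it says the series, first, only, none or still open, it means among the compounds named here.

Measured in a functional assay on SW-620 cells (Homo sapiens) for cytotoxicity, read by MTT assay, with a stated time of 72 h; on this read-out higher numbers stand for weaker inhibition and lower numbers for stronger inhibition:
- Compound 1 `COc1cccc(/C=C2\CCC/C(=C\c3ccc(Cl)cc3)C2=O)c1OC`: 11100 nM
- Compound 2 `COc1cccc(/C=C2\CCC/C(=C\c3ccccc3Br)C2=O)c1OC`: 12100 nM
- Compound 3 `COc1cccc(/C=C2\CCC/C(=C\c3cccc(Br)c3)C2=O)c1OC`: 8800 nM

Compound 3 stands level with the other two compounds, since all three values lie within the scatter of one another and allow no ranking in this assay.

The next compound, compound 4 `COc1ccc(/C=C2\CCC/C(=C\c3cccc(OC)c3OC)C2=O)cc1`, changes one aryl group of compound 3, with 4-methoxyphenyl in place of 3-bromophenyl on a double-bonded chain carbon bound to a double-bonded ring carbon.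

The three measured steps all concern this same place. They are a 1.3-fold lower number from compound 1 to compound 3 (0.10 log units; within the scatter), a 1.4-fold lower number from compound 2 to compound 3 (0.14 log units; within the scatter) and a 1.1-fold higher number from compound 1 to compound 2 (0.04 log units; within the scatter). Each of them exchanges one halogen-bearing phenyl group for another, and none moves the value beyond the scatter. Within the data shown here, no measured compound carries the 4-methoxyphenyl group, so the evidence for this exchange is indirect, and the range has to stay wide. On these steps, no change beyond the scatter is expected in this assay.

The expected move is a 1.1-fold higher number from compound 3 to compound 4 (0.03 log units; within the scatter).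

For compound 4 the estimated value is 9500 nM, with an expected range from 4500 nM to 20000 nM.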

Compound 4, half-maximal inhibitory concentration: 13600 nM
For compound 4 the middle estimate is 1.4-fold (0.16 log units) below the measured one, within the range that was stated.
By their numbers in this assay, from the lowest: compounds 3, 1, 2 and 4 (each within the scatter of the next).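

Compound 4 is the first of these compounds to carry a phenyl group without a halogen on a double-bonded chain carbon bound to a double-bonded ring carbon, and in this assay this exchange still leaves the value within the scatter, with a 1.5-fold higher number from compound 3 to compound 4 (0.19 log units; within the scatter) and a 1.1-fold higher number from compound 2 to compound 4 (0.05 log units; within the scatter) and a 1.2-fold higher number from compound 1 to compound 4 (0.09 log units; within the scatter) as the three steps. The lack of separation seen among the halogen-bearing phenyl groups therefore extends to 4-methoxyphenyl, which brings one hydrogen-bond acceptor where the 3-bromophenyl group has none, and the four compounds still allow no ranking in this assay. No information at hand bears on this result.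

On these data alone, whether an amine or a carboxylic acid on this phenyl group, or a longer chain in its place, would move the value beyond the scatter remains open. As far as these compounds go, the other aryl group on the shared core is the same in all four compounds, so the effect of an exchange there also remains open.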